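This account rests on a few compounds, and the source may have more. Where it says the series, first, only, none or still open, it means among the compounds named here.

Measured so far:
- compound 1 `CCN(CC)CN1C(=O)/C(=N/NC(=S)Nc2ccccc2)c2cc(Cl)ccc21`: 6900 nM
- compound 2 `CCN(CC)CN1C(=O)/C(=N/NC(N)=S)c2cc(Cl)ccc21`: > 100000 nM (a limit of the assay)
- compound 3 `CCN(CC)CN1C(=O)/C(=N/NC(=S)Nc2ccc(C)cc2)c2cc(Cl)ccc21`: 17500 nM

In an ADME assay on CRFK cells (Felis catus) for cytotoxicity (a higher number here means that more compound is tolerated, a lower number that less compound is tolerated), compound 3 gives 17500 nM, the higher of the two actual numbers, with compound 1 next at 6900 nM. Compound 4 `CCN(CC)CN1C(=O)/C(=N/NC(=S)Nc2ccc(Cl)cc2)c2cc(Cl)ccc21` has chloro in place of methyl on an aromatic carbon, para to a large group: chloro in place of methyl on an aromatic carbon.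

The closest measured change is methyl in place of hydrogen on an aromatic carbon, a 2.5-fold higher number from compound 1 to compound 3 (0.40 log units; beyond the scatter), a modest step. The steps of an at least 14-fold higher number from compound 1 to compound 2 (1.16 log units; beyond the scatter) and an at least 5.7-fold lower number from compound 2 to compound 3 (0.75 log units; beyond the scatter) are larger, but they exchange a whole phenyl or 4-methylphenyl for hydrogen and say little about this smaller change. Going by the values given here, no chloro compound has been measured yet, so in this assay a small move to a lower number is expected, no larger than the modest step. The expected step is a 1.6-fold lower number from compound 3 to compound 4 (0.20 log units; within the scatter). For compound 4 the estimated value is 11000 nM, with an expected range of 4500 nM to 26000 nM.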

Compound 4, half-maximal cytotoxic concentration: 9100 nM
Beside the measured number, compound 4's estimate is 1.2-fold (0.08 log units) above it; low and high end bracket the measured number.
By their numbers in this assay, from the lowest: compounds 1, 4 and 3 (each within the scatter of the next, the first and the last beyond it). At a limit, above all of these: compound 2.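

In this assay, chloro in place of methyl on an aromatic carbon, para to a large group, gives a 1.9-fold lower number from compound 3 to compound 4 (0.28 log units; within the scatter), and chloro in place of hydrogen at that carbon gives a 1.3-fold higher number from compound 1 to compound 4 (0.12 log units; within the scatter), so compound 4 cannot be told apart from either neighbour, although compound 1 and compound 3 differ beyond the scatter. Replacing hydrogen with 4-chlorophenyl on the amide-type nitrogen gives an at least 10-fold lower number from compound 2 to compound 4 (1.04 log units; beyond the scatter), so the large step seen with the phenyl and 4-methylphenyl compounds also holds with the 4-chlorophenyl compound. The value of compound 2 is a limit, so this step has no exact size: the limit of > 100000 nM in this assay, at which 1 of the 4 values shown sits.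

As far as these compounds go, whether an amine or a carboxylic acid at this carbon would move the number further than hydrogen, methyl and chloro do remains open. Also open, from the compounds shown here alone, is whether chloro on another carbon of this ring would read the same.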